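The source may report more compounds than this note shows. Statements on the series, on what has been measured and on what is new or still open speak of the compounds shown alone.

Working notes on the series sharing the core of compound 1 (`C=C1C(=O)O[C@H]2[C@H]1CC/C(COC(=O)Cn1cc(F)c(=O)n(Cc3ccc(Cl)cc3)c1=O)=C\CC[C@@]1(C)O[C@@H]21`), read in a functional assay on Bel7402/5-FU cells (Homo sapiens) for antiproliferative activity, read by MTT assay, with a stated time of 72 h; on this read-out higher numbers stand for weaker inhibition and lower numbers for stronger inhibition. Compound 1 gives 2420 nM, compound 2 (`C=C1C(=O)O[C@H]2[C@H]1CC/C(COC(=O)Cn1cc(F)c(=O)n(Cc3ccc([N+](=O)[O-])cc3)c1=O)=C\CC[C@@]1(C)O[C@@H]21`) gives 4340 nM and compound 3 (`C=C1C(=O)O[C@H]2[C@H]1CC/C(COC(=O)Cn1cc(F)c(=O)n(Cc3ccccc3F)c1=O)=C\CC[C@@]1(C)O[C@@H]21`) gives 3830 nM. Compound 3 stands within the scatter of both others, with a 1.6-fold higher number from compound 1 to compound 3 (0.20 log units; within the scatter) and a 1.1-fold lower number from compound 2 to compound 3 (0.05 log units; within the scatter). Compound 4 (`C=C1C(=O)O[C@H]2[C@H]1CC/C(COC(=O)Cn1cc(F)c(=O)n(Cc3c(F)cccc3F)c1=O)=C\CC[C@@]1(C)O[C@@H]21`) differs from compound 3 at one place, 2-fluorobenzyl to 2,6-difluorobenzyl: fluoro in place of hydrogen on an aromatic carbon, ortho to a large group and meta to a fluoro group, (fluoro in place of hydrogen on an aromatic carbon).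

Within the data shown here, no measured step adds a fluoro to the aromatic ring, so the evidence is indirect. The nearest steps are those that change the substituents on this same ring: the two above, and a 1.8-fold higher number from compound 1 to compound 2 (0.25 log units; within the scatter). All three stay within the scatter, although they exchange chloro, nitro and fluoro substitution. On that basis, no step beyond the scatter and no particular direction is expected for the added fluoro. The expected step is a 1.1-fold lower number from compound 3 to compound 4 (0.04 log units; within the scatter). In this assay, the estimate for compound 4 is 3500 nM, with an expected range of 1800 nM to 6800 nM.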

Compound 4, half-maximal inhibitory concentration: 4980 nM
For compound 4 the middle estimate is 1.4-fold (0.15 log units) below the measured one; the range from low to high includes it.
By their numbers in this assay, from the lowest: compounds 1, 3, 2 and 4 (each within the scatter of the next, the first and the last beyond it).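

In this assay, placing a fluoro on an aromatic carbon ortho to a large group and meta to a fluoro group gives a 1.3-fold higher number from compound 3 to compound 4 (0.11 log units; within the scatter), so this hydrogen-to-fluoro exchange, the only direct one among the compounds shown, does not move the number beyond the scatter. The 2,6-difluorobenzyl group also stays within the scatter against 4-nitrobenzyl, with a 1.1-fold higher number from compound 2 to compound 4 (0.06 log units; within the scatter), but against 4-chlorobenzyl it gives a 2.1-fold higher number from compound 1 to compound 4 (0.31 log units; beyond the scatter), a modest step and the only one in the series beyond the scatter, even though compound 3 lies within the scatter of both compound 1 and compound 4. No measurement is available that bears on the origin of these steps.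

On these data alone, the unsubstituted benzyl group remains open as a reference for both fluoro groups, as does a 2,4-difluorobenzyl group for the placement of the second fluoro. Also open, as far as these compounds go, is whether an amine or a carboxylic acid on this ring, or a longer chain in place of the benzyl methylene, would give steps larger than those seen with the chloro, nitro and fluoro groups.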